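The compounds below may be only part of what the source reports. "The series", "measured", "known", "first", "only" and "open" are said of these compounds alone.

In a functional assay on SH-SY5Y cells (Homo sapiens) for cytotoxicity, with a stated time of 24 h (on this read-out higher numbers stand for weaker inhibition and lower numbers for stronger inhibition), compound 1 `CCC1C=Cc2c(cc(C)oc2=O)O1` reads > 200000 nM, which is a limit and not a number. Among the compounds with values here, compound 2 `Cc1cc2c(c(=O)o1)C=C(C(C)C)C(CC(C)C)O2` gives 6700 nM, the only actual number so far. Compound 3 `Cc1cc2c(c(=O)o1)C=C(c1ccccc1)C(CC(C)C)O2` has phenyl in place of isopropyl on a double-bonded ring carbon. Within the data shown here, no measured pair tests this kind of change, so any forecast is tentative, and no shift beyond the scatter is expected in this assay. The expected change is a 1.1-fold lower number from compound 2 to compound 3 (0.05 log units; within the scatter). For compound 3 the estimated value is 6000 nM, with an expected range of 1800 nM to 25000 nM.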

Compound 3, half-maximal inhibitory concentration: 93000 nM
Compound 3: middle estimate off by 16-fold (1.19 log units), on the low side, and the stated range ends below it.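

On the double-bonded ring carbon, phenyl in place of isopropyl is not a neutral swap in this assay: the step is a 14-fold higher number from compound 2 to compound 3 (1.14 log units; beyond the scatter). Within the data shown here, this is the first measured sign that the read-out responds to the group at this position, and here the phenyl group goes with weaker inhibition. Room for further rises on this read-out is bounded: the limit of > 200000 nM in this assay, at which 1 of the 3 values shown sits.

As far as these compounds go, whether the rise follows the aromatic ring or simply the carbon count stays open, and a cyclohexyl group here would separate the two. From the compounds shown here alone, how an amine on the phenyl ring would read is also open.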